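Shrinking the amine substituent on compound 2

The source may hold more compounds than are shown below. What is called first, only, known or untested is meant among the compounds shown, and "the series" means these compounds.

Compound 2 `CC(C)(C)Nc1nccc(C(C)(C)C)n1`: 26%
Compound 1 `CC(C)(C)c1ccnc(NCc2ccccc2)n1`: 14%

In a functional assay on the whole organism for inhibition, with Rattus norvegicus as the target, with stated times of 1 h and 3.5 h, at a dose of 100 mg/kg by the oral route (a higher number here means more inhibition at the dose given (going by the name of the read-out), a lower number less inhibition), compound 2 gives 26%, the highest of the two numbers, while compound 1 gives 14%, a lower number that lies beyond the scatter. Compound 3 `CNc1nccc(C(C)(C)C)n1` differs from compound 2 in one place: methyl in place of tert-butyl on a nitrogen on an aromatic ring. Among the measured compounds shown here, no measured pair shows what this change does, so the expected step from compound 2 to compound 3 is a number 8 percentage points lower from compound 2 to compound 3 (within the scatter), a modest drop of uncertain size. Compound 3 is therefore estimated at 18%, within a range from 5% to 32%.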

Compound 3, a percentage reported as inhibition, in the whole organism at one dose (the size of the read-out at that dose, not a potency): 34%
Compound 3: middle estimate off by 16 percentage points, on the low side; the whole stated range lies below it.
By their numbers in this assay, from the lowest: compound 1; then compounds 2 and 3 (each within the scatter of the next).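

In this assay, the nitrogen on the aromatic ring accepts a far smaller group without a clear loss: methyl in place of tert-butyl gives a number 8 percentage points higher from compound 2 to compound 3 (within the scatter) and so reads as no real change. Losing the phenyl from the chain carbon does count, with a number 20 percentage points higher from compound 1 to compound 3 (beyond the scatter) as the result, so the phenyl of compound 1 is the one change here that separates two compounds clearly. Nothing available explains either step. As far as these compounds go, what an ethyl group or a plain amino group on this nitrogen would give remains open.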